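Replacing 2-methoxyphenyl with 3,4-dihydroxyphenyl on compound 3

A few compounds are considered here, and "the series" means these few. Any claim that something is new, unique, unknown or untested is made for them only; others in the source may bear on it.

In a functional assay on A549 cells (Homo sapiens) for inhibition, read by MTT assay, with a stated time of 72 h (a lower number here means a stronger inhibitor, a higher number a weaker inhibitor), compound 1 `COc1cc(/C=C/C(=O)c2c(OC)cc(O)c(CC=C(C)C)c2O)cc(OC)c1OC` reads > 50000 nM as a limit of the assay and not a number. Compound 2 `COc1cc(O)c(CC=C(C)C)c(O)c1C(=O)/C=C/c1ccc(Cl)cc1` gives 11800 nM as its half-maximal inhibitory concentration, and compound 3 `COc1cc(OC)c(C(=O)/C=C/c2ccccc2OC)c(OC)c1` gives 19800 nM on the same read-out. These two values lie within the usual scatter of each other, so compound 3 stands level with compound 2 on the numbers available.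

Compound 4 `COc1cc(OC)c(C(=O)/C=C/c2ccc(O)c(O)c2)c(OC)c1` has not yet been measured. It differs from compound 3 in one place, with 3,4-dihydroxyphenyl in place of 2-methoxyphenyl on a double-bonded chain carbon bound to a double-bonded chain carbon. Within the data shown here, no two measured compounds differ in only one place, so the data offer no step to go by, and no change beyond the scatter is expected in either direction. The estimated step of a 1.3-fold lower number from compound 3 to compound 4 (0.12 log units; within the scatter) is expected to stay within that scatter. Compound 4 is estimated at 15000 nM and expected to lie between 5000 nM and 45000 nM.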

Compound 4, half-maximal inhibitory concentration: 8200 nM
Beside the measured number, compound 4's estimate is 1.8-fold (0.26 log units) above it; low and high end bracket the measured number.
By their numbers in this assay, from the lowest: compounds 4, 2 and 3 (each within the scatter of the next, the first and the last beyond it). At a limit, above all of these: compound 1.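

In this assay, among these compounds, the change from 2-methoxyphenyl to 3,4-dihydroxyphenyl on a double-bonded chain carbon bound to a double-bonded chain carbon gives a 2.4-fold lower number from compound 3 to compound 4 (0.38 log units; beyond the scatter) as the first step in this set that can be read at a single place. Among the earlier compounds no two differed in only one place, so this position had no reading of its own; it now shows that this exchange moves the number beyond the scatter. Nothing measured here accounts for the size or direction of this step.

This single step cannot separate the loss of the methoxy group from the gain of the two hydroxyl groups, nor say whether one hydroxyl group alone would give the same number. Going by these compounds, whether a group bearing an amine or a carboxylic acid at this place would move the number further, in either direction, also stays open.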